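The source may report more compounds than this note shows. Statements on the series, on what has been measured and on what is new or still open speak of the compounds shown alone.

Measured so far:
compound 1, `Cc1ccc(-c2nc(N)c3cc(Cc4ccccc4)sc3n2)o1` — 298 nM
compound 2, `Cc1ccc(-c2nc(N)c3cc(Cc4ccccc4F)sc3n2)o1` — < 16 nM

Among the measured compounds shown here, compound 1 gives the only number in a functional assay on CHO-K1 cells for antagonist activity at adenosine receptor A1 (Homo sapiens), read by a beta-galactosidase reporter and cAMP accumulation, with stated times of 15 min and 6 h; on this read-out higher numbers stand for weaker inhibition and lower numbers for stronger inhibition. Compound 2 returns a limit of this assay, (the limit of < 16 nM in this assay, at which 1 of the 2 values shown sits), not a number. For the measured compounds named here, the one measured step, an at least 18-fold lower number from compound 1 to compound 2 (1.27 log units; beyond the scatter), is a fluoro in place of hydrogen on an aromatic carbon and does not touch the part of the structure changed here.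

Compound 3, `Nc1nc(-c2cnco2)nc2sc(Cc3ccccc3)cc12`, carries 1,3-oxazol-5-yl in place of 5-methylfuran-2-yl on an aromatic carbon. Going by the values given here, no measured step bears on this change; nothing shows which way the number moves or by how much. The working expectation is therefore a number near that of compound 1, with a wide range in either direction. Compound 3 is estimated at 400 nM in this assay, from 80 nM to 2500 nM. This is expected to amount to a 1.3-fold higher number from compound 1 to compound 3 (0.13 log units; within the scatter), within the scatter.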

Compound 3, inhibition constant: 106 nM
For compound 3 the middle estimate is 3.8-fold (0.58 log units) above the measured one; the measured number falls inside the stated range.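

On an aromatic carbon between two ring nitrogen atoms, 1,3-oxazol-5-yl in place of 5-methylfuran-2-yl gives in this assay a 2.8-fold lower number from compound 1 to compound 3 (0.45 log units; beyond the scatter) as a modest step. Among the compounds shown here, this is the first reading at this position: on this single pair, the 5-methylfuran-2-yl group is not needed for inhibition, and the ring with 2 hetero atoms goes with the lower number. No measured property at hand accounts for this step.

The pair changes the ring and removes the methyl at once, so a plain furan-2-yl or a 2-methyl-1,3-oxazol-5-yl would be needed to separate the two changes. Also open, from the compounds shown here alone, are six-membered rings such as phenyl or pyridin-2-yl here, and whether the fluoro of compound 2 adds to 1,3-oxazol-5-yl.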